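The source may hold more compounds than are shown below. What is called first, only, known or untested is meant among the compounds shown, and "the series" means these compounds.

Values measured in a functional assay (strain AB) with Danio rerio as the target, read by microscopy, with a stated time of 1 h (a higher number here means that more compound is needed for the effect, a lower number that less compound is needed), follow.

Compound 1 `CCN1CCc2c(sc(NC(=O)Nc3ccc4ccccc4c3)c2C(N)=O)C1` gives 1780 nM
Compound 2 `NC(=O)c1c(NC(=O)Nc2ccc(Cl)cc2)sc2c1CCN(CC1CCCCC1)C2` gives 1890 nM
Compound 3 `CCN1CCc2c(sc(NC(=O)Nc3cccc(C)c3)c2C(N)=O)C1` gives 13000 nM

Of these three numbers, compound 2 stands close to compound 1, the two lying within the usual scatter of each other, while compound 3 stands higher than both, beyond the scatter.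

Compound 4 `CC(C)(C)OC(=O)CCN1CCc2c(sc(NC(=O)Nc3ccc(Cl)cc3)c2C(N)=O)C1` has not yet been measured. It departs from compound 2 on a saturated chain carbon bound to an amine nitrogen in a ring, where (tert-butoxycarbonyl)methyl stands in place of cyclohexyl ((tert-butoxycarbonyl)methyl in place of cyclohexyl on a saturated chain carbon bound to an amine nitrogen in a ring). Cut one bond further out, the same difference reads cyclohexylmethyl to 2-(tert-butoxycarbonyl)ethyl.

Going by the values given here, no two measured compounds differ in one place only, so the data offer no direct guide to this change. The gap between compound 1 at 1780 nM and compound 3 at 13000 nM argues for a broad range. The estimated step is a 1.6-fold higher number from compound 2 to compound 4 (0.20 log units; within the scatter), expected to be a small one towards a higher number. For compound 4 the expected value is 3000 nM, with an estimated range from 800 nM to 12000 nM.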

Compound 4, half-maximal effective concentration: 1100 nM
Estimate against measurement, compound 4: 2.7-fold (0.44 log units) above; low and high end bracket the measured number.
By their numbers in this assay, from the lowest: compounds 4, 1 and 2 (each within the scatter of the next); then compound 3.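

In this assay, going by these compounds alone, this is the first pair of compounds that differ in one place only, and the change gives a 1.7-fold lower number from compound 2 to compound 4 (0.24 log units; within the scatter). On this pair, therefore, a saturated ring of carbon on the chain carbon bound to the ring amine nitrogen can give way to an open (tert-butoxycarbonyl)methyl group, with two hydrogen-bond acceptors, and the number stays within the usual scatter. No measurement at hand explains why the two groups read alike.

As far as these compounds go, whether a carboxylic acid or an amine in the place of the (tert-butoxycarbonyl)methyl group would also read like this remains open. So does whether the same swap would behave in the same way on compounds that differ elsewhere, since this is a single pair.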